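Swapping 2,6-dimethylphenyl for 1,3-thiazol-2-yl on a shared core

This account rests on a few compounds, and the source may have more. Where it says the series, first, only, none or still open, it means among the compounds named here.

In a functional assay on HCT-8 cells (Homo sapiens) for cytotoxicity (a lower number here means that less compound is needed, a higher number that more compound is needed for the effect), compound 1 `COC1=C(C)C(=O)/C(=C(O)/C=C/c2ccc(OC)cc2)C(=O)C1(C)C` gives 5.6 ug/mL while compound 2 `COC1=C(C)C(=O)/C(=C(O)/C=C/c2ccc(O)cc2)C(=O)C1(C)C` gives 14.8 ug/mL and compound 3 `COC1=C(C)C(=O)/C(=C(O)/C=C/c2c(C)cccc2C)C(=O)C1(C)C` gives 7.8 ug/mL on the same scale. Compound 3 sits within the scatter of both others: a 1.4-fold higher number from compound 1 to compound 3 (0.14 log units; within the scatter) and a 1.9-fold lower number from compound 2 to compound 3 (0.28 log units; within the scatter) are the two ring swaps at this place. Only a 2.6-fold higher number from compound 1 to compound 2 (0.42 log units; beyond the scatter) is a clear gap, and that change is on an oxygen, not a ring swap. Compound 4 `COC1=C(C)C(=O)/C(=C(O)/C=C/c2nccs2)C(=O)C1(C)C` brings 1,3-thiazol-2-yl in place of 2,6-dimethylphenyl on a double-bonded chain carbon bound to a double-bonded chain carbon as its change, so 1,3-thiazol-2-yl in place of 2,6-dimethylphenyl. Going by the values given here, no measured compound carries a five-membered ring, so the only guide is the two ring swaps that end at compound 3 with 7.8 ug/mL as the starting value. The expected outcome is a 1.0-fold higher number from compound 3 to compound 4 (0.01 log units; within the scatter) and thus no step beyond the scatter. In this assay the estimate for compound 4 is 8 ug/mL with a range from 3.5 ug/mL to 18 ug/mL expected.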

Compound 4, concentration for half-maximal effect: 5.1 ug/mL
Beside the measured number, compound 4's estimate is 1.6-fold (0.20 log units) above it; the range from low to high includes it.
By their numbers in this assay, from the lowest: compounds 4, 1, 3 and 2 (each within the scatter of the next, the first and the last beyond it).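

At this place, on a double-bonded chain carbon bound to a double-bonded chain carbon, a five-membered aromatic ring with 2 hetero atoms does as well in this assay as the six-membered carbon rings, since neither of these steps leaves the scatter (a 1.5-fold lower number from compound 3 to compound 4 (0.18 log units; within the scatter); a 1.1-fold lower number from compound 1 to compound 4 (0.04 log units; within the scatter)). Going by these compounds alone, only the step from the 4-hydroxyphenyl ring is a clear one (a 2.9-fold lower number from compound 2 to compound 4 (0.46 log units; beyond the scatter)). No measurement here explains this result. Going by these compounds, whether a ring is needed at this place at all stays open: an amine, a carboxylic acid or a longer chain could answer that.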